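A few compounds are considered here, and "the series" means these few. Any claim that something is new, unique, unknown or untested is made for them only; others in the source may bear on it.

Compound 1 `CSc1nc(N)c2nn(C3O[C@H](CO)[C@@H](O)[C@H]3O)nc2n1` gives 25000 nM
Compound 2 `CS(=O)(=O)c1nc(N)c2nn(C3O[C@H](CO)[C@@H](O)[C@H]3O)nc2n1` gives 22000 nM

In a functional assay on HEp-2 cells (Homo sapiens) for cytotoxicity (on this read-out higher numbers stand for weaker inhibition and lower numbers for stronger inhibition), compound 2 gives 22000 nM and stands within the scatter of compound 1. Compound 3 `Nc1nc(N)c2nn(C3O[C@H](CO)[C@@H](O)[C@H]3O)nc2n1` carries amino in place of methylsulfonyl on an aromatic carbon and keeps the rest of the core. Among the compounds with values here, the one measured step on that carbon (a 1.1-fold lower number from compound 1 to compound 2 (0.06 log units; within the scatter)) stayed within the scatter, but no amino compound has been measured, so this guide is thin. No step beyond the scatter is therefore expected in this assay, and the expected step is small (a 1.1-fold higher number from compound 2 to compound 3 (0.06 log units; within the scatter)). Compound 3 is estimated at 25000 nM with an expected range from 9000 nM to 70000 nM in this read-out.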

Compound 3, half-maximal inhibitory concentration: > 75000 nM
Compound 3 ended at the assay's limit; the forecaster's own chance of this, stated with the estimate: 15%; middle value at least 3.0-fold (0.47 log units) from the limit.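

In this assay, the group on this aromatic carbon turns out to matter: methylsulfanyl and methylsulfonyl stayed within the scatter of each other, but amino in place of methylsulfonyl gives an at least 3.4-fold higher number from compound 2 to compound 3 (0.53 log units; beyond the scatter), and amino in place of methylsulfanyl gives an at least 3.0-fold higher number from compound 1 to compound 3 (0.47 log units; beyond the scatter). Inhibition is therefore weaker with amino than with either of the other two groups. Compound 3 gives a limit of the assay rather than a number, so the full size of both steps stays unknown: the limit of > 75000 nM in this assay, at which 1 of the 3 values shown sits.

From the compounds shown here alone, whether this weakening is specific to amino remains open. A methylamino group, a hydroxyl group or a chlorine atom on this carbon could help to settle that.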